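Replacing a Methyl Ester with a Quinolinylmethyl Ester

The compounds below may be only part of what the source reports. "The series", "measured", "known", "first", "only" and "open" are said of these compounds alone.

Compound 1 `CC1=C(C(=O)OCc2ccccc2)C(c2ccc(Cl)cc2Cl)NC(=O)N1CCCC(=O)OCc1ccccc1F` and compound 2 `COC(=O)CCCN1C(=O)NC(c2ccc(Cl)cc2Cl)C(C(=O)OCc2ccccc2)=C1C` share one core and differ only in the group on the saturated chain carbon bound to an oxygen next to a carbonyl group. In an ADME assay on MCF7 cells (Homo sapiens) for cytotoxicity, read by CellTiter-Glo, with a stated time of 24 h (on this read-out lower numbers stand for stronger inhibition of growth and higher numbers for weaker inhibition of growth), compound 1 gives > 100000 nM and this is a limit of the assay rather than a measured number. In this assay compound 2 gives > 300000 nM and this too is a limit rather than a number. The step that the two limits leave unreadable from compound 1 to compound 2 therefore cannot be read, as both compounds sit at limits recorded by the limit of > 100000 nM in this assay, at which 1 of the 2 values shown sits, and the limit of > 300000 nM in this assay, at which 1 of the 2 values shown sits, in turn. Compound 2 thus stands at a limit, with no measured number among the values shown.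

Compound 3 `CC1=C(C(=O)OCc2ccccc2)C(c2ccc(Cl)cc2Cl)NC(=O)N1CCCC(=O)OCc1ccc2ccccc2n1` arises from compound 2 through the change quinolin-2-yl in place of hydrogen on a saturated chain carbon bound to an oxygen next to a carbonyl group at that position. For the measured compounds named here, the only measured step touching this position is a step that the two limits leave unreadable from compound 1 to compound 2 and it has no readable size, so it gives no direction for the new group. With both measured compounds at limits, compound 3 is expected to show no growth inhibition that this assay can quantify, and the expected step of an at least 2.0-fold lower number from compound 2 to compound 3 (0.30 log units; that floor lies within the scatter) is estimated as no change beyond the scatter. Compound 3 is estimated at 150000 nM with a range from 30000 nM to 600000 nM in this assay.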

Compound 3, concentration for 50% growth inhibition: > 100000 nM
Compound 3: no number, only a limit (the forecaster's own chance of this, stated with the estimate: 70%); the middle value lies beyond the limit too.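

In this assay compound 3 gives > 100000 nM, which is a limit of the assay and not a number. Compound 1 and compound 2 also stand at limits, and the steps linking them to compound 3 cannot be read. Going by these compounds, it stays open whether quinolin-2-yl, 2-fluorophenyl or hydrogen at this place differ at all in growth inhibition in this assay.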